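This account rests on a few compounds, and the source may have more. Where it says the series, first, only, none or still open, it means among the compounds named here.

The shared core of compound 2 `C/N=C(\S)CCn1nc(-c2ccccc2)ccc1=O` carries a short chain on the ring nitrogen that ends in a thioamide-type group. In a functional assay on the whole organism (stomach) with Rattus norvegicus as the target (on this read-out higher numbers stand for an effect only at larger amounts of compound and lower numbers for an effect already at smaller amounts), compound 2 gives 58.5 mg/kg. That is the lowest of the two numbers available, with compound 1 `N=C(S)CCn1nc(-c2ccccc2)ccc1=S` nearest to it. Compound 1 gives 73.4 mg/kg in this assay, a gap that lies within the scatter. Compound 3 `C/N=C(\S)CCn1ncccc1=O` reports only a limit in this assay, > 100 mg/kg. Among the measured compounds shown here, the one measured step, an at least 1.7-fold higher number from compound 2 to compound 3 (0.23 log units; that floor lies within the scatter), concerns the phenyl group, and because of the limit of > 100 mg/kg in this assay, at which 1 of the 3 values shown sits, its size is known only as a floor.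

Compound 4 `N=C(S)CCCCCCn1nc(-c2ccccc2)ccc1=O` differs from compound 2 at the chain: a group of 7 heavy atoms (5 carbon, 1 nitrogen, 1 sulfur; no ring) in place of a group of 4 heavy atoms (2 carbon, 1 nitrogen, 1 sulfur; no ring), on a saturated chain carbon, two bonds along the chain from an aromatic nitrogen. For the measured compounds named here, no measured step touches the chain between the ring nitrogen and the thioamide-type end, so the pair of compounds 1 and 2 offers the only guidance, and their values sit within the scatter of one another. The expectation for this assay is therefore a step of no clear direction, a 1.0-fold higher number from compound 2 to compound 4 (0.01 log units; within the scatter), with wide uncertainty. Compound 4 is estimated at 60 mg/kg in this assay, within a range from 25 mg/kg to 140 mg/kg.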

Compound 4, dose for half-maximal effect: > 100 mg/kg
Compound 4 was reported as a limit; the forecaster's own chance of this, stated with the estimate: 30%; at least 1.6-fold (0.22 log units) between middle value and limit.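

Among the compounds shown here, the change at the saturated chain carbon, two bonds along the chain from an aromatic nitrogen, is the first measured step at this position, and in this assay it gives an at least 1.7-fold higher number from compound 2 to compound 4 (0.23 log units; that floor lies within the scatter). Its size is known only as a floor, and that floor lies within the scatter, because of a value that is a limit and not a number: the limit of > 100 mg/kg in this assay, at which 2 of the 4 values shown sit. The chain position thus joins the phenyl group as a second place where a single change from compound 2 leads to a limit rather than a number, though neither step can be shown to exceed the scatter.

The entering group differs from the leaving group in more than its size, with 2 hydrogen-bond donors against 1, and the compounds shown leave open whether the step follows the longer chain or the changed end of the group. They also leave open how a chain of intermediate length would read out, or how an amine or a carboxylic acid would do in place of the thioamide-type end.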